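Variation of the pendant aryl group: cytotoxicity notes

The source may report more compounds than this note shows. Statements on the series, on what has been measured and on what is new or still open speak of the compounds shown alone.

Measured compounds, cytotoxicity in an ADME assay on MT4 cells (Homo sapiens) for cytotoxicity, read by MTT assay, with a stated time of 4 days; a lower number here means that less compound is tolerated, a higher number that more compound is tolerated:
compound 1 `Cc1cc(-c2cccc(C(F)(F)F)c2)cc(C)c1Nc1ccnc(Nc2ccc(C#N)cc2)n1` gives 4030 nM
compound 2 `Cc1cc(-c2cccc(C#N)c2)cc(C)c1Nc1ccnc(Nc2ccc(C#N)cc2)n1` gives 920 nM
compound 3 `Cc1ccc(-c2cc(C)c(Nc3ccnc(Nc4ccc(C#N)cc4)n3)c(C)c2)cc1` gives 5570 nM

On these three numbers compound 3 stands highest in this assay; against compound 1 the difference is within the scatter, against compound 2 it is beyond it. The relevant steps are a 1.4-fold higher number from compound 1 to compound 3 (0.14 log units; within the scatter) and a 6.1-fold higher number from compound 2 to compound 3 (0.78 log units; beyond the scatter), so exchanging the pendant aryl group has so far moved the number by no more than a modest amount, and only the 3-cyanophenyl case stands apart.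

Compound 4 `COc1cccc(-c2cc(C)c(Nc3ccnc(Nc4ccc(C#N)cc4)n3)c(C)c2)c1` differs from compound 3 by 3-methoxyphenyl in place of 4-methylphenyl on an aromatic carbon. For the measured compounds named here, no measured step introduces a methoxy group, so nothing directly bears on this change; the two steps above only show that a group on the pendant ring can shift the number modestly in either direction or not at all. The expectation for compound 4 in this assay is therefore a step of about a 1.4-fold lower number from compound 3 to compound 4 (0.14 log units; within the scatter), which stays within the scatter of compound 3.

Compound 4 is estimated at 4000 nM in this assay, with a range from 1500 nM to 10000 nM.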

Compound 4, half-maximal cytotoxic concentration: 2990 nM
For compound 4 the middle estimate is 1.3-fold (0.13 log units) above the measured one; the range from low to high includes it.
By their numbers in this assay, from the lowest: compound 2; then compounds 4, 1 and 3 (each within the scatter of the next).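

In this assay the 3-methoxyphenyl group joins the 3-(trifluoromethyl)phenyl and 4-methylphenyl groups in one cluster on the aromatic carbon meta to two methyl groups: the change gives a 1.9-fold lower number from compound 3 to compound 4 (0.27 log units; within the scatter) and a 1.3-fold lower number from compound 1 to compound 4 (0.13 log units; within the scatter), and both steps stay within the scatter. Against the 3-cyanophenyl case the same compound gives a 3.3-fold higher number from compound 2 to compound 4 (0.51 log units; beyond the scatter), so compound 2 now stands apart from all three other compounds, and methoxy in place of cyano moves the number upward much as the other two pendant groups do. No measured evidence here bears on why cyano separates from the other groups.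

The step to compound 4 changes both the group and its place on the pendant ring, so a 3-methylphenyl or 4-methoxyphenyl group would be needed to read these two changes apart. Also open is how this cytotoxicity number responds when the pendant ring carries an amine, a carboxylic acid or a longer alkoxy chain, none of which resembles the groups shown so far.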